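Trimming the ester acyl group: cytotoxicity expectation

The source may hold more compounds than are shown below. What is called first, only, known or untested is meant among the compounds shown, and "the series" means these compounds.

Measured compounds:
- Compound 1, `Cc1cn([C@H]2CO[C@@H](COC(=O)C3CCCCC3)O2)c(=O)[nH]c1=O`; in an ADME assay on PBMC cells (Homo sapiens) for cytotoxicity, read by MTT assay, with a stated time of 3 days (a higher number here means a weaker inhibitor, a lower number a stronger inhibitor), compound 1 gives > 100000 nM, a limit of the assay rather than a number.
- Compound 2, `CCCCCCCCCCCC(=O)OC[C@@H]1OC[C@H](n2cc(C)c(=O)[nH]c2=O)O1`; in this assay compound 2 gives > 100000 nM, again a limit.
- Compound 3, `CCCCCCCC(=O)OC[C@@H]1OC[C@H](n2cc(C)c(=O)[nH]c2=O)O1`; in this assay compound 3 gives > 100000 nM, again a limit.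

Compound 1 therefore stands at a limit, as do both of its neighbours, which is summed up by the limit of > 100000 nM in this assay, at which 3 of the 3 values shown sit. The two steps that reach compound 3 are a step that the two limits leave unreadable from compound 1 to compound 3 and a step that the two limits leave unreadable from compound 2 to compound 3; neither can be sized, since each end is a limit.

Compound 4, `CC(=O)OC[C@@H]1OC[C@H](n2cc(C)c(=O)[nH]c2=O)O1`, differs from compound 1 by methyl in place of cyclohexyl on a carbonyl carbon. This change runs in the same direction as the shortening between the measured esters, whose sizes stay hidden. Nothing in the shown values suggests any measurable cytotoxicity within the tested range.

For compound 4 the expectation in this assay is 200000 nM, with a plausible range from 100000 nM to 1000000 nM, most likely reported only as a limit again. The estimated step that the limit leaves unreadable from compound 1 to compound 4 is expected to be none beyond the scatter.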

Compound 4, half-maximal inhibitory concentration: > 100000 nM
Compound 4 gave a limit, no number (the forecaster's own chance of this, stated with the estimate: 90%); the middle value is on the limit's open side.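

No step can be read from compound 1 or compound 3 to compound 4, because both ends of each comparison are limits: the limit of > 100000 nM in this assay, at which 4 of the 4 values shown sit.

Whether changing the acyl group of the ester shifts the result in this assay at all stays open with the compounds shown.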